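Extending the Chain of Compound 2 Toward Compound 4

This account rests on a few compounds, and the source may have more. Where it says the series, first, only, none or still open, it means among the compounds named here.

Among the compounds with values here, compound 2 `CC(C#Cc1cccc(C(=O)NCc2ccccc2C(F)(F)F)c1)N(O)C(N)=O` gives 700 nM in an assay for inhibition of Polyunsaturated fatty acid 5-lipoxygenase (Homo sapiens), read by HPLC, with stated times of 15 min and 10 min (on this read-out higher numbers stand for weaker inhibition and lower numbers for stronger inhibition), the lowest of the three numbers measured so far. Compound 1 `Cc1ccc(C(=O)NCc2ccccc2C(F)(F)F)cc1C#CC(C)N(O)C(N)=O` gives 1700 nM, and the step from it shows a 2.4-fold lower number from compound 1 to compound 2 (0.39 log units; beyond the scatter). Compound 3 `CC(C#Cc1cccc(C(=O)NCc2ccc(F)cc2C(F)(F)F)c1)N(O)C(N)=O` gives 1300 nM, with a 1.9-fold higher number from compound 2 to compound 3 (0.27 log units; within the scatter). Compound 4 `CC(C)CC(C#Cc1cccc(C(=O)NCc2ccccc2C(F)(F)F)c1)N(O)C(N)=O` differs from compound 2 by isopropyl in place of hydrogen on a saturated chain carbon, two bonds along the chain from an amide-type nitrogen and a triple-bonded carbon. Within the data shown here, both measured steps alter an aromatic substituent and neither touches the saturated chain, so no measured step bears on this change and the data give no direction for it. The step of a 1.3-fold higher number from compound 2 to compound 4 (0.11 log units; within the scatter) is therefore expected to be small, with its direction uncertain. The estimate for compound 4 is 900 nM, within a range from 200 nM to 4000 nM.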

Compound 4, half-maximal inhibitory concentration: 600 nM
Compound 4: the middle estimate sits 1.5-fold (0.18 log units) above what was measured, and the stated range covers the measured number.
By their numbers in this assay, from the lowest: compounds 4, 2, 3 and 1 (each within the scatter of the next, the first and the last beyond it).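

The first change shown on the saturated chain, isopropyl in place of hydrogen, gives a 1.2-fold lower number from compound 2 to compound 4 (0.07 log units; within the scatter) in this assay. This carbon therefore accepts a group of 3 heavy atoms, turning methyl into isobutyl, with no step beyond the scatter. Nothing available explains this result.

As far as these compounds go, it remains open whether a longer chain, a phenyl ring or an amine on this carbon would also leave the number within the scatter. From the compounds shown here alone, it is also open whether the aromatic methyl and fluoro steps would read the same with the isobutyl group present.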